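Fluoropyridine for fluorophenyl on the shared core

A few compounds are considered here, and "the series" means these few. Any claim that something is new, unique, unknown or untested is made for them only; others in the source may bear on it.

Compound 1 `NC(=O)[C@@H]1[C@H](Nc2nc(Nc3cccc(C(=O)N4CCCC4)c3)ncc2-c2ccoc2)[C@H]2C=C[C@@H]1C2` gives 40 nM
Compound 2 `NC(=O)[C@@H]1[C@H](Nc2nc(Nc3cccc(C(=O)N4CCCC4)c3)ncc2-c2ccc(F)cc2)[C@H]2C=C[C@@H]1C2` gives 460 nM

For the measured compounds named here, in a functional assay on THP-1 cells (Homo sapiens) for inhibition, read by ELISA, with stated times of 1 h and 18 h (on this read-out lower numbers stand for stronger inhibition and higher numbers for weaker inhibition), compound 2 stands at 460 nM as the higher of the two numbers so far, and compound 1 gives 40 nM on the same read-out. The next compound is compound 3 `NC(=O)[C@@H]1[C@H](Nc2nc(Nc3cccc(C(=O)N4CCCC4)c3)ncc2-c2cncc(F)c2)[C@H]2C=C[C@@H]1C2` which differs from compound 2 by one group (5-fluoropyridin-3-yl in place of 4-fluorophenyl on an aromatic carbon), with 5-fluoropyridin-3-yl in place of 4-fluorophenyl on an aromatic carbon. Going by the values given here, only one measured step bears on this place: a 12-fold higher number from compound 1 to compound 2 (1.06 log units; beyond the scatter) is large and beyond the scatter, and it came with 4-fluorophenyl in place of furan-3-yl. Among the compounds with values here, no measured compound yet carries a six-membered aromatic ring with a hetero atom at this place. Compound 3 keeps the six-membered ring of compound 2 yet holds a hetero atom as the furan-3-yl of compound 1 does, so its number is expected between the two, nearer compound 2 at 460 nM than compound 1 at 40 nM on this evidence. A modest move to a lower number is expected, estimated as a 2.3-fold lower number from compound 2 to compound 3 (0.36 log units; beyond the scatter). Compound 3 is estimated at 200 nM with an expected range of 60 nM to 650 nM on this assay as the read-out.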

Compound 3, half-maximal inhibitory concentration: 170 nM
Estimate against measurement, compound 3: 1.2-fold (0.07 log units) above; the measured number falls inside the stated range.
By their numbers in this assay, from the lowest: compound 1; then compound 3; then compound 2.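

In this assay, 5-fluoropyridin-3-yl in place of 4-fluorophenyl gives a 2.7-fold lower number from compound 2 to compound 3 (0.43 log units; beyond the scatter) and thus shows that this place, ortho to a large group on the aromatic ring, responds to a change inside a six-membered aromatic ring of the same heavy-atom count, where the entering ring holds a hetero atom and a hydrogen-bond acceptor and the leaving ring holds neither. The six-membered ring with a hetero atom does not match the furan-3-yl, however: a 4.3-fold higher number from compound 1 to compound 3 (0.63 log units; beyond the scatter) and this leaves compound 1 with the lowest number of the three, its steps to both others lying beyond the scatter. No measurement here gives a reason for either step.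

The compounds shown leave open whether the ring nitrogen or the changed place of the fluorine carries the step, as the two change together here and a plain pyridin-3-yl or a 3-fluorophenyl group would part them. On these data alone, it also remains open whether the lower number of compound 1 goes with the five-membered ring or with its oxygen, a question on which a thiophen-3-yl group would bear.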